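The source may report more compounds than this note shows. Statements on the series, on what has been measured and on what is new or still open speak of the compounds shown alone.

Compound 1 `CC1(C)C=C(n2ccccc2=O)c2cc(S(=O)(=O)N=[N+]=[N-])ccc2O1`: 88.3%
Compound 2 `CNS(=O)(=O)c1ccc2c(c1)C(n1ccccc1=O)=CC(C)(C)O2`: 85.8%

Among the compounds with values here, compound 2 stands lowest of the two numbers in a functional assay on the whole organism (aorta) with Rattus norvegicus as the target (on this read-out lower numbers stand for smaller maximal responses and higher numbers for larger maximal responses), but the only measured step onto it is within the scatter: a number 2.5 percentage points lower from compound 1 to compound 2 (within the scatter). That step exchanged azido for methylamino on the sulfonyl sulfur.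

Compound 3 `CC1(C)C=C(n2ccccc2=O)c2cc(S(=O)(=O)NCCO)ccc2O1` differs from compound 2 by hydroxymethyl in place of hydrogen on a saturated chain carbon bound to a sulfonamide nitrogen. Within the data shown here, no measured step touches the saturated chain carbon bound to the sulfonamide nitrogen, so the one step that bears on the sulfonamide region is the exchange on the sulfonyl sulfur, and that step stayed within the scatter. Compound 3 is therefore expected to show no step beyond the scatter in this assay, a number 0.2 percentage points higher from compound 2 to compound 3 (within the scatter). For compound 3 the estimate in this assay is 86%, with a range from 74% to 96%, pending the measurement.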

Compound 3, largest response reached (Emax), in percent of the reference or control that the assay uses: 95.5%
Beside the measured number, compound 3's estimate is 9.5 percentage points below it, within the range that was stated.
By their numbers in this assay, from the lowest: compounds 2, 1 and 3 (each within the scatter of the next).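

In this assay, going from methyl to 2-hydroxyethyl gives a number 9.7 percentage points higher from compound 2 to compound 3 (within the scatter) and so shows that hydroxymethyl can enter on the saturated chain carbon bound to the sulfonamide nitrogen without a step beyond the scatter. Putting (2-hydroxyethyl)amino in place of azido on the sulfonyl sulfur gives a number 7.2 percentage points higher from compound 1 to compound 3 (within the scatter) and thus leaves azido, methylamino and (2-hydroxyethyl)amino on the sulfonyl sulfur all within the scatter of one another on the shared core. Nothing available explains these numbers or gives a reason for either step.

On these data alone, whether a longer chain such as 3-hydroxypropyl, or a 2-aminoethyl or carboxymethyl group in place of 2-hydroxyethyl, would produce a step beyond the scatter stays open. The compounds shown also leave open how these sulfonyl groups would behave on a different core.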